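This account rests on a few compounds, and the source may have more. Where it says the series, first, only, none or still open, it means among the compounds named here.

Compound 2, `O=C(c1ccc(F)cc1)N1CCC(NCCSC(c2ccc(F)cc2)c2ccc(F)cc2)CC1`, gives 7.04 nM in an assay on membranes from striatum (strain Sprague-Dawley) for displacement of a labelled ligand from sodium-dependent dopamine transporter (Rattus norvegicus), read by scintillation counting, with a stated time of 120 min (on this read-out lower numbers stand for stronger inhibition and higher numbers for weaker inhibition), and so stands at the lower of the two numbers measured. For the measured compounds named here, compound 1, `Fc1ccc(CN2CCC(NCCSC(c3ccc(F)cc3)c3ccc(F)cc3)CC2)cc1`, gives 25.5 nM in this assay, and a 3.6-fold lower number from compound 1 to compound 2 (0.56 log units; beyond the scatter) is the only measured step; it concerns the link to the ring nitrogen, not the group on the carbonyl, so it does not bear directly on the change now in question. Compound 3, `CC(C)(C)C(=O)N1CCC(NCCSC(c2ccc(F)cc2)c2ccc(F)cc2)CC1`, differs from compound 2 by tert-butyl in place of 4-fluorophenyl on a carbonyl carbon. Going by the values given here, with no measured step touching the substituent on the carbonyl carbon, the direction of the change is not settled by the data. For compound 3 a step of a 2.1-fold higher number from compound 2 to compound 3 (0.33 log units; beyond the scatter) is expected, a modest weakening that may still fall within the usual scatter. Compound 3 is therefore estimated at 15 nM in this assay, with a range from 4 nM to 55 nM.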

Compound 3, inhibition constant: 352 nM
Estimate against measurement, compound 3: 23-fold (1.37 log units) below; the measured number lies above the stated range.
By their numbers in this assay, from the lowest: compound 2; then compound 1; then compound 3.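

Replacing 4-fluorophenyl with tert-butyl on the carbonyl carbon gives a 50-fold higher number from compound 2 to compound 3 (1.70 log units; beyond the scatter) in this assay and is a large step, so the group on the carbonyl carbon counts for much more than the modest earlier step suggested. The (tert-butyl)carbonyl also compares poorly with the 4-fluorobenzyl, with a 14-fold higher number from compound 1 to compound 3 (1.14 log units; beyond the scatter) as a second large step, so among these compounds a carbonyl on the ring nitrogen goes with the lowest number only when it carries 4-fluorophenyl. No evidence at hand explains the size of these steps.

The compounds shown leave open whether the loss follows the removal of the aromatic ring or the arrival of tert-butyl specifically. A cyclohexyl or an unsubstituted phenyl on the carbonyl carbon would help separate these two readings.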